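Trimethylsilyl in Place of Pentylphenyl on the Triazole

The compounds below may be only part of what the source reports. "The series", "measured", "known", "first", "only" and "open" are said of these compounds alone.

Measured compounds:
Compound 1, `O=C1O/C(=C\Cn2cc(-c3cc(F)cc(F)c3)nn2)C(OCc2ccccc2)=C1OCc1ccccc1`: > 100000 nM
Compound 2, `CCCCCc1ccc(-c2cn(C[C@H](O)[C@H]3OC(=O)C(OCc4ccccc4)=C3OCc3ccccc3)nn2)cc1`: > 100000 nM
Compound 3, `CC(C)(C)OC(=O)N1CCN(C(=S)SCc2cn(C[C@H](O)[C@H]3OC(=O)C(OCc4ccccc4)=C3OCc3ccccc3)nn2)CC1`: 60 nM

All three compounds were tested in an ADME assay on HFF cells (Homo sapiens) for cytotoxicity, read by MTT assay, with a stated time of 72 h; on this read-out higher numbers stand for weaker inhibition and lower numbers for stronger inhibition. Compound 2 gives only a limit here, > 100000 nM, and not a number. Compound 1 likewise sits at a limit, > 100000 nM. Compound 3, by contrast, gives a measured number, 60 nM, and is the only one of the three to do so; the other two rest at the limit of > 100000 nM in this assay, at which 2 of the 3 values shown sit. Among the compounds with values here, no pair among the measured compounds differs in a single place, so no step between them can be computed.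

Compound 4, `C[Si](C)(C)c1cn(C[C@H](O)[C@H]2OC(=O)C(OCc3ccccc3)=C2OCc2ccccc2)nn1`, has not yet been measured in this assay. It differs from compound 2 as follows: a group of 4 heavy atoms (3 carbon, 1 silicon; no ring) in place of a group of 11 heavy atoms (11 carbon; one six-membered aromatic ring of carbon only), on an aromatic carbon. The compounds shown give no basis for attaching a direction to this change, and compound 2 itself offers only a limit to start from. The expectation for compound 4 is therefore that it behaves like compound 2, with the step of a number no higher from compound 2 to compound 4 (the limit leaves the size open) expected to lie within the scatter. Compound 4 is estimated at 100000 nM, ranging from 30000 nM to 300000 nM, with a good chance that this assay again reports only a limit.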

Compound 4, half-maximal inhibitory concentration: 20000 nM
Estimate against measurement, compound 4: 5.0-fold (0.70 log units) above; the measured number lies below the stated range.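

In this assay, within the data shown here, trimethylsilyl in place of 4-pentylphenyl gives an at least 5.0-fold lower number from compound 2 to compound 4 (0.69 log units; beyond the scatter), the first step that can be read at this aromatic carbon of the five-membered aromatic ring with 3 nitrogen. It shows that the group at this position can bring a compound of this series off the limit and onto a measured value, here with a group of fewer heavy atoms and no ring, so the position is not silent in this read-out. The true size of the step stays unknown because compound 2 gives only a limit, and the step therefore sets a minimum and no more: the limit of > 100000 nM in this assay, at which 2 of the 4 values shown sit.

One step cannot tell whether the change follows from the silicon atom, from the loss of the aromatic ring, or from the loss of the pentyl chain. A tert-butyl group, with carbon in place of the silicon, and a plain phenyl group, without the pentyl chain, would separate these readings, and the compounds shown leave open whether either would stay at the limit or fall to a measured value.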